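The compounds below may be only part of what the source reports. "The series", "measured", "known", "first", "only" and "open" are said of these compounds alone.

In a functional assay on HepG2 cells (Homo sapiens) for antiproliferative activity, read by MTT assay, with a stated time of 24 h (on this read-out lower numbers stand for stronger inhibition and higher numbers for weaker inhibition), compound 1 (`COc1cc(OC)c(-c2coc3cc(OCc4ccc(C#N)cc4)ccc3c2=O)cc1OC`) gives 4230 nM and compound 2 (`COc1cc(OC)c(-c2coc3cc(OCc4ccc(Cl)cc4)ccc3c2=O)cc1OC`) gives 940 nM (the lower of the two numbers), so compound 2 is the stronger of this pair. Compound 3 (`COc1cc(OC)c(-c2coc3cc(OCc4ccccc4Cl)ccc3c2=O)cc1OC`) is not yet measured. Its difference from compound 2 (2-chlorophenyl in place of 4-chlorophenyl on a saturated chain carbon bound to an oxygen on an aromatic ring) is 2-chlorophenyl in place of 4-chlorophenyl on a saturated chain carbon bound to an oxygen on an aromatic ring, with the shared core unchanged. Among the compounds with values here, the only measured step (a 4.5-fold lower number from compound 1 to compound 2 (0.65 log units; beyond the scatter)) puts chloro in place of cyano on an aromatic carbon. Within the data shown here, it bears on the new change only indirectly, since it swaps one group for another and no measured pair shows what moving the chlorine does. That step therefore sets only a rough scale, and a shift no larger than it is expected in this assay. The direction is not settled by the data, with a slightly higher number taken as the working expectation. The estimated step (a 1.4-fold higher number from compound 2 to compound 3 (0.14 log units; within the scatter)) is expected to stay small. The value for compound 3 is estimated at 1300 nM (expected range 500 nM to 3500 nM).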

Compound 3, half-maximal inhibitory concentration: 1690 nM
Estimate against measurement, compound 3: 1.3-fold (0.11 log units) below, and the stated range covers the measured number.
By their numbers in this assay, from the lowest: compounds 2 and 3 (each within the scatter of the next); then compound 1.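

In this assay, moving the chlorine gives a 1.8-fold higher number from compound 2 to compound 3 (0.25 log units; within the scatter), so 4-chlorophenyl and 2-chlorophenyl cannot be told apart on this read-out, and this first comparison of the two placements shows no demand for one of them at this position on the saturated chain carbon. The advantage over the 4-cyanophenyl group of compound 1 is not confined to the 4-chlorophenyl group, since the change to 2-chlorophenyl gives a 2.5-fold lower number from compound 1 to compound 3 (0.40 log units; beyond the scatter), a step that also lies beyond the scatter. Nothing measured in the series gives a reason for either step.

From the compounds shown here alone, whether chlorine itself contributes remains open, since the series holds no comparison with a plain phenyl group at this place, and the two chlorophenyl compounds alone cannot separate a benefit of chlorine from a penalty of the nitrile. Also untested in these compounds are an amine or a carboxylic acid on the aromatic ring in place of chlorine, and a longer chain between the oxygen and that ring.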